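Compound 3 to compound 4: vinyl in place of 4-aminophenyl

The source may report more compounds than this note shows. Statements on the series, on what has been measured and on what is new or still open speak of the compounds shown alone.

Values in a functional assay on KYSE-70 cells for antiproliferative activity against KYSE-70 cell line (Homo sapiens), read by MTT assay, with a stated time of 72 h; a higher number here means a weaker inhibitor, a lower number a stronger inhibitor:
compound 1 `O=C(Nc1cccc(F)c1)c1cc(=O)[nH]c2cc(Br)ccc12`: 8900 nM
compound 2 `O=C(Nc1cccc(F)c1)c1cc(=O)[nH]c2cc(F)ccc12`: > 20000 nM (a limit)
compound 3 `Nc1ccc(-c2ccc3c(C(=O)Nc4cccc(F)c4)cc(=O)[nH]c3c2)cc1`: > 20000 nM (a limit)
compound 4 `C=Cc1ccc2c(C(=O)Nc3cccc(F)c3)cc(=O)[nH]c2c1`: not yet measured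

Compound 3 gives only a limit, > 20000 nM, and no number. Compound 4 carries vinyl in place of 4-aminophenyl on an aromatic carbon. For the measured compounds named here, two measured steps bear on this change, an at least 2.2-fold higher number from compound 1 to compound 2 (0.35 log units; beyond the scatter) and an at least 2.2-fold higher number from compound 1 to compound 3 (0.35 log units; beyond the scatter), each beyond the scatter, while a step that the two limits leave unreadable from compound 2 to compound 3 gives no size. Both replacements of bromo raised the number, so compound 4 is expected to stay nearer compound 3 than compound 1 in this assay. The expected step is small and, if readable, towards a lower number: an at least 1.3-fold lower number from compound 3 to compound 4 (0.12 log units; that floor lies within the scatter). For compound 4 the estimate is 15000 nM, with an expected range of 6000 nM to 35000 nM.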

Compound 4, half-maximal inhibitory concentration: 9700 nM
For compound 4 the middle estimate is 1.5-fold (0.19 log units) above the measured one; measured number inside the range.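

In this assay, for the compounds shown here, vinyl is the first replacement of bromo on this aromatic carbon that leaves the read-out level with bromo, with a 1.1-fold higher number from compound 1 to compound 4 (0.04 log units; within the scatter). Vinyl also separates from 4-aminophenyl, with an at least 2.0-fold lower number from compound 3 to compound 4 (0.31 log units; beyond the scatter), and from fluoro, with an at least 2.0-fold lower number from compound 2 to compound 4 (0.31 log units; beyond the scatter). Compound 2 and compound 3 both give only a limit, so these two steps are floors and the step between those compounds cannot be read, because both rest on the same limit: the limit of > 20000 nM in this assay, at which 2 of the 4 values shown sit.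

Open, on these data alone, is whether ethyl, ethynyl or an amine set directly on this carbon would read with bromo and vinyl or with fluoro.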